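Nitrophenyl position in the aroyl series: notes

The compounds below may be only part of what the source reports. "The series", "measured", "known", "first", "only" and "open" are said of these compounds alone.

- compound 1 `COc1cc(C(=O)c2cn(-c3cccc(C)c3)cc2-c2ccc([N+](=O)[O-])cc2)cc(OC)c1OC` at 780 nM
- compound 2 `COc1cc(C(=O)c2cn(-c3ccc(N)cc3)cc2-c2cccc([N+](=O)[O-])c2)cc(OC)c1OC` at 260 nM

In a functional assay on MCF7 cells (Homo sapiens) for cytotoxicity, read by MTT assay, with a stated time of 96 h (on this read-out lower numbers stand for stronger inhibition and higher numbers for weaker inhibition), compound 2 holds the lower number of the two, and its gap to compound 1 lies beyond the scatter. Next in line is compound 3 `COc1cc(C(=O)c2cn(-c3ccc(N)cc3)cc2-c2ccc([N+](=O)[O-])cc2)cc(OC)c1OC` which carries 4-nitrophenyl in place of the 3-nitrophenyl of compound 2 on an aromatic carbon 4-nitrophenyl in place of 3-nitrophenyl on an aromatic carbon and keeps everything else. Among the measured compounds shown here, no measured pair isolates this change. Compound 1 also bears 4-nitrophenyl and gives 780 nM in this assay but that offers only a weak hint of an upward drift. The step of a 1.2-fold higher number from compound 2 to compound 3 (0.06 log units; within the scatter) is therefore expected to stay within the scatter, with no firm direction. The estimated value for compound 3 is 300 nM within an expected range of 90 nM to 1000 nM on this read-out.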

Compound 3, half-maximal inhibitory concentration: 260 nM
Compound 3: the middle estimate sits 1.2-fold (0.06 log units) above what was measured; measured number inside the range.
By their numbers in this assay, from the lowest: compounds 2 and 3 (each within the scatter of the next); then compound 1.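

In this assay the pair compound 2 and compound 3 isolates 4-nitrophenyl in place of 3-nitrophenyl on an aromatic carbon, and the step reads no change at the digits printed from compound 2 to compound 3 (within the scatter) so this change leaves the number in place on the 4-aminophenyl background. With 4-nitrophenyl held fixed, 4-aminophenyl in place of 3-methylphenyl on an aromatic nitrogen gives a 3.0-fold lower number from compound 1 to compound 3 (0.48 log units; beyond the scatter) so among these compounds the group on the nitrogen, not the nitrophenyl isomer, is the change with a step beyond the scatter. No supporting measurement offers a reason for either step.

Going by these compounds, whether this carbon responds as little to a phenyl bearing an amine or a carboxylic acid in place of the nitro group stays open. The same holds for the nitrogen with groups such as 3-aminophenyl or 4-hydroxyphenyl.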